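Fused-ring aryl amide in a bisindole cytotoxic series

The source may report more compounds than this note shows. Statements on the series, on what has been measured and on what is new or still open speak of the compounds shown alone.

The two measured compounds share one core and differ only in the group attached to the amide carbonyl. Compound 1 `COc1ccc(C(=O)NC[C@H]2c3[nH]c4ccccc4c3C[C@H]3[C@H]4c5[nH]c6ccccc6c5C[C@@H]([C@H](C#N)N23)N4C)cc1` carries a methoxy-substituted phenyl ring and gives 600 nM in a functional assay on MCF7 cells (Homo sapiens) for cytotoxicity, read by MTT assay, with a stated time of 72 h; a lower number here means a stronger inhibitor, a higher number a weaker inhibitor. Among the compounds with values here, compound 2 `CCc1ccc(C(=O)NC[C@H]2c3[nH]c4ccccc4c3C[C@H]3[C@H]4c5[nH]c6ccccc6c5C[C@@H]([C@H](C#N)N23)N4C)cc1` carries an ethyl-substituted phenyl ring instead and gives 170 nM in this assay, so compound 2 stands at the lower of the two numbers, with compound 1 as its only neighbour; the step of a 3.5-fold lower number from compound 1 to compound 2 (0.55 log units; beyond the scatter) moved the number by a modest amount, beyond the scatter.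

Compound 3 `CN1[C@@H]2c3[nH]c4ccccc4c3C[C@H]1[C@H](C#N)N1[C@@H](CNC(=O)c3cccc4c3CCCC4)c3[nH]c4ccccc4c3C[C@@H]21` has not yet been measured. Its change from compound 2 is 1,2,3,4-tetrahydronaphthalen-5-yl in place of 4-ethylphenyl on a carbonyl carbon. Within the data shown here, no measured step exchanges a whole aryl group at this carbonyl; the only step known, from compound 1 to compound 2, swaps one substituent on that ring and was modest. A step of similar scale or none beyond the scatter is therefore expected here, with a slightly weaker number judged somewhat more likely, so compound 3 is estimated at 250 nM in this assay, within 80 nM to 800 nM, meaning an expected step of a 1.5-fold higher number from compound 2 to compound 3 (0.17 log units; within the scatter).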

Compound 3, half-maximal inhibitory concentration: 4470 nM
Estimate against measurement, compound 3: 18-fold (1.25 log units) below; the measured number lies above the stated range.
By their numbers in this assay, from the lowest: compound 2; then compound 1; then compound 3.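

The group on the carbonyl carbon matters far more in this assay than the earlier substituent swap suggested: replacing 4-ethylphenyl with 1,2,3,4-tetrahydronaphthalen-5-yl gives a large step (a 26-fold higher number from compound 2 to compound 3 (1.42 log units; beyond the scatter)), well beyond the modest one seen before (a 3.5-fold lower number from compound 1 to compound 2 (0.55 log units; beyond the scatter)). The same exchange starting from the 4-methoxyphenyl group also raises the number (a 7.5-fold higher number from compound 1 to compound 3 (0.87 log units; beyond the scatter)), so compound 3 is the weakest of the three, and this position clearly does not treat all carbon-only aryl groups alike. No measurement shown gives a reason for this rise.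

The compounds shown leave open whether the rise comes from the added non-aromatic ring itself or from the way the 1,2,3,4-tetrahydronaphthalen-5-yl group as a whole is joined to the carbonyl carbon. An unsubstituted phenyl ring, a fully aromatic naphthyl group, or a phenyl ring carrying a longer chain such as propyl or an amine would help separate these two readings.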